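A few compounds are considered here, and "the series" means these few. Any claim that something is new, unique, unknown or untested is made for them only; others in the source may bear on it.

In an ADME assay on cells (Astrocyte, Homo sapiens) for cytotoxicity, read by WST assay, with a stated time of 72 h (on this read-out higher numbers stand for weaker inhibition and lower numbers for stronger inhibition), compound 1 `O=C(Nc1ccc(C(F)(F)F)cc1)Nc1cc2ncncc2cc1OCc1cccc(F)c1` gives 8900 nM and compound 2 `O=C(Nc1ccc(Cl)c(Cl)c1)Nc1cc2ncncc2cc1OCc1ccccc1F` gives 3900 nM, the lower of the two numbers, with a gap beyond the usual scatter. For compound 3 `O=C(Nc1cc2ncncc2cc1OCc1ccc(Cl)cc1)Nc1cccc2ccccc12` the assay reports only a limit, > 10000 nM. Compound 4 `O=C(Nc1ccc(Cl)c(Cl)c1)Nc1cc2ncncc2cc1OCc1cccc(F)c1` differs from compound 2 in one place, with 3-fluorophenyl in place of 2-fluorophenyl on a saturated chain carbon bound to an oxygen on an aromatic ring. Among the compounds with values here, no measured pair shows this change alone, so the expectation starts from compound 2 at 3900 nM. The expected step of a 1.3-fold higher number from compound 2 to compound 4 (0.11 log units; within the scatter) is small, toward a higher number, and stays within the scatter. Compound 4 is estimated at 5000 nM, with an expected range of 2200 nM to 10000 nM.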

Compound 4, half-maximal inhibitory concentration: 7400 nM
The estimate for compound 4 lay 1.5-fold (0.17 log units) below the measured number; the range from low to high includes it.
By their numbers in this assay, from the lowest: compounds 2, 4 and 1 (each within the scatter of the next, the first and the last beyond it). At a limit, above all of these: compound 3.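

Moving the fluorine, from 2-fluorobenzyl to 3-fluorobenzyl, gives a 1.9-fold higher number from compound 2 to compound 4 (0.28 log units; within the scatter), while 3,4-dichlorophenyl in place of 4-(trifluoromethyl)phenyl gives a 1.2-fold lower number from compound 1 to compound 4 (0.08 log units; within the scatter). Each single change thus stays within the scatter, even though compound 1 and compound 2, which differ in both places, lie beyond it. One value in this small set is only a limit: the limit of > 10000 nM in this assay, at which 1 of the 4 values shown sits.

Still open, from the compounds shown here alone, is whether a plain benzyl, or a benzyl carrying an amine or a carboxylic acid, would move the number beyond the scatter.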